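Arylidene thiosemicarbazone in place of the free hydrazine

A few compounds are considered here, and "the series" means these few. Any claim that something is new, unique, unknown or untested is made for them only; others in the source may bear on it.

Compound 1 `CC1=CC[C@@H]([C@@](C)(O)CCCC(C)(C)NC(=S)NN)CC1` gives the highest number of the three measured, 49400 nM in a functional assay on HT-29 cells (Homo sapiens) for cytotoxicity, read by sulforhodamine B assay; a lower number here means a stronger inhibitor of growth, a higher number a weaker inhibitor of growth. Compound 2 `CC1=CC[C@@H]([C@@](C)(O)CCCC(C)(C)NC(=S)N/N=C\c2cccc(Cl)c2)CC1` gives 6890 nM, and compound 3 `CC1=CC[C@@H]([C@@](C)(O)CCCC(C)(C)NC(=S)N/N=C\c2ccc(Cl)cc2)CC1` gives 7350 nM. Compound 4 `CC1=CC[C@@H]([C@@](C)(O)CCCC(C)(C)NC(=S)N/N=C(/C)c2ccccc2)CC1` differs from compound 1 by a group of 9 heavy atoms (8 carbon, 1 nitrogen; one six-membered aromatic ring of carbon only) in place of one nitrogen atom, on an amide-type nitrogen. Among the measured compounds shown here, the steps that bear on this change are a 7.2-fold lower number from compound 1 to compound 2 (0.86 log units; beyond the scatter) and a 6.7-fold lower number from compound 1 to compound 3 (0.83 log units; beyond the scatter), both modest and beyond the scatter, while the two chlorophenyl analogues differ by only a 1.1-fold higher number from compound 2 to compound 3 (0.03 log units; within the scatter), within the scatter. The entering group of compound 4 carries no chlorine, a difference the measured pairs do not cover. Compound 4 is therefore expected to show a step of similar size, a 5.5-fold lower number from compound 1 to compound 4 (0.74 log units; beyond the scatter). Compound 4 is estimated at 9000 nM, with a range from 4000 nM to 25000 nM.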

Compound 4, concentration for 50% growth inhibition: 28400 nM
Beside the measured number, compound 4's estimate is 3.2-fold (0.50 log units) below it; measured number outside the range, above it.
By their numbers in this assay, from the lowest: compounds 2 and 3 (each within the scatter of the next); then compounds 4 and 1 (each within the scatter of the next).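

At this amide-type nitrogen, an entering group with a six-membered aromatic ring does not by itself give a step beyond the scatter in this assay, as a 1.7-fold lower number from compound 1 to compound 4 (0.24 log units; within the scatter) shows. The group of compound 4 stands apart from the chlorophenyl groups, with a 3.9-fold higher number from compound 3 to compound 4 (0.59 log units; beyond the scatter) and a 4.1-fold higher number from compound 2 to compound 4 (0.62 log units; beyond the scatter). Nothing measured here explains this difference.

Compound 4 lacks chlorine and carries a methyl on the carbon with a double bond to nitrogen, and the compounds shown do not separate these two changes. A plain benzylidene group on the same nitrogen would separate them.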